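A few compounds are considered here, and "the series" means these few. Any claim that something is new, unique, unknown or untested is made for them only; others in the source may bear on it.

Measured compounds:
compound 1, `CC(CNCC1CC1)Oc1cccc2ccc(N)nc12`: 460 nM
compound 2, `CC(CNCC1CCCC1)Oc1cccc2ccc(N)nc12`: 100 nM
compound 3, `CC(CNCc1ccccc1)Oc1cccc2ccc(N)nc12`: 340 nM

The three measured compounds share one core and differ only in the group carried on the saturated chain carbon bound to the amine nitrogen. In a functional assay on IMR-32 cells with melanin-concentrating hormone receptor 1 (Homo sapiens) as the target, read by fluorescence (on this read-out lower numbers stand for stronger inhibition and higher numbers for weaker inhibition), compound 3 gives 340 nM, the second highest of the three numbers. Its nearest neighbour is compound 1, and the step of a 1.4-fold lower number from compound 1 to compound 3 (0.13 log units; within the scatter) keeps both within the scatter of each other. Its furthest neighbour is compound 2, with the step of a 3.4-fold higher number from compound 2 to compound 3 (0.53 log units; beyond the scatter); the related step of a 4.6-fold lower number from compound 1 to compound 2 (0.66 log units; beyond the scatter) points the same way, so among the groups tried the cyclopentyl stands out, while phenyl and cyclopropyl do not separate.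

Compound 4, `COc1cccc(CNCC(C)Oc2cccc3ccc(N)nc23)c1`, differs from compound 3 by methoxy in place of hydrogen on an aromatic carbon. Among the compounds with values here, none of the measured steps touches the phenyl ring itself; all of them swap the whole group on that chain carbon. The data therefore give no direct guide to adding a methoxy, and the step of a 1.4-fold lower number from compound 1 to compound 3 (0.13 log units; within the scatter) suggests that this part of the molecule tolerates change without large effects. The step from compound 3 to compound 4 is accordingly expected to be a 1.1-fold lower number from compound 3 to compound 4 (0.05 log units; within the scatter), none beyond the scatter. Compound 4 is expected to give 300 nM, in a range from 100 nM to 1000 nM.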

Compound 4, half-maximal inhibitory concentration: 600 nM
Estimate against measurement, compound 4: 2.0-fold (0.30 log units) below; measured number inside the range.
By their numbers in this assay, from the lowest: compound 2; then compounds 3, 1 and 4 (each within the scatter of the next).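

In this assay the only substitution shown on the phenyl ring itself, a methoxy on an aromatic carbon meta to a large group, gives the step of a 1.8-fold higher number from compound 3 to compound 4 (0.25 log units; within the scatter) and so does not separate 3-methoxyphenyl from phenyl at this position. The step of a 1.3-fold higher number from compound 1 to compound 4 (0.12 log units; within the scatter) likewise leaves 3-methoxyphenyl level with cyclopropyl, whereas the step of a 6.0-fold higher number from compound 2 to compound 4 (0.78 log units; beyond the scatter) adds a third comparison in which cyclopentyl stands apart, making compound 2 the most potent of the four, while compounds 1, 3 and 4 do not separate along the steps printed for them. No measurement shown here explains these numbers.

On these data alone, it remains open whether a methoxy elsewhere on the phenyl ring, or another group on it such as a fluorine, a hydroxyl or a nitrile, would move the number beyond the scatter. As far as these compounds go, it also remains open whether the lower number seen with cyclopentyl extends to a cyclohexyl or a cyclobutyl on the same chain carbon, or whether it is confined to the cyclopentyl alone.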